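Extending the Acetyl of Compound 3 by One Carbon

The compounds below may be only part of what the source reports. "The series", "measured", "known", "first", "only" and "open" are said of these compounds alone.

Values measured in an assay on HEK293 cells for negative allosteric modulation of metabotropic glutamate receptor 5 (Homo sapiens), read by FLIPR, with a stated time of 1 h; a higher number here means a weaker inhibitor, a lower number a stronger inhibitor:
Compound 1, `CN1CCc2nc(C#Cc3ccccc3)sc2C1`, gives > 10000 nM, which is a limit of the assay.
Compound 2, `CCCCN1CCc2nc(C#Cc3ccccc3)sc2C1`, gives > 10000 nM, which is also a limit of the assay.
Compound 3, `CC(=O)N1CCc2nc(C#Cc3ccccc3)sc2C1`, gives 90 nM.

Among the measured compounds shown here, compound 3 therefore holds the only real number among the three; the other two values sit at a limit, (the limit of > 10000 nM in this assay, at which 2 of the 3 values shown sit). Compound 4, `CCC(=O)N1CCc2nc(C#Cc3ccccc3)sc2C1`, has not been tested. It differs from compound 3 by methyl in place of hydrogen on a saturated chain carbon bound to a carbonyl carbon, that is, acetyl becomes propanoyl.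

Which measured steps bear on this change? The two large steps, an at least 110-fold lower number from compound 1 to compound 3 (2.04 log units; beyond the scatter) and an at least 110-fold lower number from compound 2 to compound 3 (2.04 log units; beyond the scatter), both concern the exchange of an alkyl group for acetyl on the amine nitrogen in the ring; they do not touch the chain on the carbonyl side. The step that the two limits leave unreadable from compound 1 to compound 2, methyl to butyl on that same nitrogen, cannot be read from its two limits. For the measured compounds named here, no measured step thus follows the change from compound 3 to compound 4, and the carbonyl that accompanies the large drop is kept.

On that basis the step of no change at the digits printed from compound 3 to compound 4 (within the scatter) is expected to stay within the usual scatter. Compound 4 is expected to give about 90 nM, with a range from 30 nM to 300 nM.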

Compound 4, half-maximal inhibitory concentration: 38 nM
Compound 4: the middle estimate sits 2.4-fold (0.37 log units) above what was measured; measured number inside the range.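

In this assay, among the compounds shown here, the chain on the carbonyl side, which no earlier pair of compounds touched, proves able to move the number: methyl in place of hydrogen on a saturated chain carbon bound to a carbonyl carbon gives a 2.4-fold lower number from compound 3 to compound 4 (0.37 log units; beyond the scatter) and so a modest gain from a single added carbon. Propanoyl on the amine nitrogen in the ring also stands well apart from both alkyl groups, with an at least 260-fold lower number from compound 2 to compound 4 (2.42 log units; beyond the scatter) and with an at least 260-fold lower number from compound 1 to compound 4 (2.42 log units; beyond the scatter) as the two large steps, so acetyl is no longer the only acyl group with a measured number in this series. Compound 1 and compound 2 each stand at a limit of the assay and not at a number: the limit of > 10000 nM in this assay, at which 2 of the 4 values shown sit.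

On these data alone, whether the gain continues along the chain stays open, since a longer chain such as butanoyl or a branched one such as isobutyryl could carry it further or reverse it. As far as these compounds go, it also stays open whether a carbonyl attached to a carbon chain is what matters on that nitrogen, a question that a methyl carbamate or a methyl urea in the same place would address.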